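This account rests on a few compounds, and the source may have more. Where it says the series, first, only, none or still open, it means among the compounds named here.

In an assay on isolated protein for displacement of a labelled ligand from secreted frizzled-related protein 1 (Homo sapiens), read by fluorescence polarization, with a stated time of 30 min (on this read-out higher numbers stand for weaker inhibition and lower numbers for stronger inhibition), compound 2 `N#Cc1cccc(S(=O)(=O)N2CCC(NS(=O)(=O)c3cc(S(=O)(=O)c4ccccc4)ccc3C(F)(F)F)CC2)c1` gives 90 nM, the lower of the two numbers recorded so far, while compound 1 `O=C(c1cccc(Cl)c1)N1CCC(NS(=O)(=O)c2cc(S(=O)(=O)c3ccccc3)ccc2C(F)(F)F)CC1` gives 300 nM. Going by the values given here, the one known step at this position, a 3.3-fold lower number from compound 1 to compound 2 (0.52 log units; beyond the scatter), shows that swapping the group on the ring amine nitrogen moves the result only modestly. Compound 3 `O=C(C1CCNCC1)N1CCC(NS(=O)(=O)c2cc(S(=O)(=O)c3ccccc3)ccc2C(F)(F)F)CC1` differs from compound 2 by (piperidin-4-yl)carbonyl in place of (3-cyanophenyl)sulfonyl on an amine nitrogen in a ring. Among the compounds with values here, no measured step covers a group of this kind, so the expectation rests on that single modest change, and a step of a 4.4-fold higher number from compound 2 to compound 3 (0.65 log units; beyond the scatter) in this assay is expected, toward a somewhat higher number. Compound 3 is estimated at 400 nM, within 100 nM to 1500 nM.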

Compound 3, half-maximal inhibitory concentration: 120 nM
Beside the measured number, compound 3's estimate is 3.3-fold (0.52 log units) above it; the measured number falls inside the stated range.
By their numbers in this assay, from the lowest: compounds 2 and 3 (each within the scatter of the next); then compound 1.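

In this assay the change on the ring amine nitrogen, a 1.3-fold higher number from compound 2 to compound 3 (0.12 log units; within the scatter) and so within the scatter, shows that this position can carry a group with no aromatic ring and no sulfonyl. Read on the carbonyl carbon, piperidin-4-yl in place of 3-chlorophenyl gives a 2.5-fold lower number from compound 1 to compound 3 (0.40 log units; beyond the scatter) and thus a modest gain without the sulfonyl link. Nothing available explains either result.

On these data alone, whether piperidin-4-yl would behave the same on a sulfonyl stays open. So does the outcome with a carboxylic acid or a plain methyl on that carbonyl carbon.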